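The compounds below may be only part of what the source reports. "The series", "measured", "known", "first", "only" and "open" are said of these compounds alone.

Measured compounds in an assay on Sf21 cells for inhibition of ubiquitin carboxyl-terminal hydrolase 7 (Homo sapiens), read by spectrophotometry, with stated times of 30 min and 2 h; on this read-out lower numbers stand for stronger inhibition and higher numbers for weaker inhibition:

- compound 1, `COC(=O)c1ccc(N2CCC(O)(Cn3cnc4c(Br)n(C)nc4c3=O)CC2)c(Cl)c1`: 157 nM
- compound 2, `COC(=O)C(c1ccccc1Cl)N1CCC(O)(Cn2cnc3c(cnn3-c3ccc(F)cc3)c2=O)CC1`: "not determined" (no result reported)
- compound 3, `O=c1c2cnn(-c3ccc(F)cc3)c2ncn1CC1(O)CCN(Cc2ccc(F)cc2)CC1`: "not determined" (no result reported)

Within the data shown here, compound 1 is the only member of the set with a number in this assay, and its value of 157 nM is the sole anchor. Among the measured compounds shown here, compound 3 has no single number, its entry in this assay reading "not determined" (no result reported); compound 2 likewise has none, its entry reading "not determined" (no result reported), so nothing can be said about where compound 3 stands relative to the others, and no step between measured compounds is available.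

Compound 4, `O=c1c2cnn(-c3ccc(F)cc3)c2ncn1CC1(O)CCN(Cc2ccc(Br)cc2)CC1`, differs from compound 3 in one place: bromo in place of fluoro on an aromatic carbon. The change is bromo in place of fluoro on an aromatic carbon, para to a large group, and sits on the benzyl arm at the far end of the shared core.

For the measured compounds named here, with no step of this kind among the measured compounds, the expectation is that the change produces no shift beyond the usual scatter in this assay, in either direction. Compound 4 is therefore expected to give roughly 300 nM in this assay, with a broad range from 50 nM to 3000 nM, the width reflecting the absence of any measured reference for compound 3.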

Compound 4, half-maximal inhibitory concentration: 6700 nM
For compound 4 the middle estimate is 22-fold (1.35 log units) below the measured one, and the stated range ends below it.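

No step can be read between compound 3 and compound 4: in this assay compound 3 has no single number. The compounds shown leave open how 4-fluorobenzyl and 4-bromobenzyl compare on the shared core. No evidence at hand bears on this result.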